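The source may report more compounds than this note shows. Statements on the series, on what has been measured and on what is new or still open speak of the compounds shown alone.

In an assay on isolated protein for inhibition of Aromatase (Homo sapiens), read by fluorescence, using NADPH, with a stated time of 30 min, tested at 50 uM (on this read-out higher numbers stand for more inhibition at the one concentration tested (going by the name of the read-out) and lower numbers for less inhibition), compound 1 `Cn1c(-c2ccc(Cl)c(Cl)c2)cc2cc(N)ccc21` gives 42%.
Compound 2 `Cn1c(-c2ccc(Cl)c(Cl)c2)cc2cc([N+](=O)[O-])ccc21` gives 34%.
Compound 3 `O=[N+]([O-])c1ccc2[nH]c(-c3ccc(Cl)c(Cl)c3)cc2c1` gives 7.59%.

All three measured compounds carry the same dichlorophenyl-bearing bicyclic core, and differ only in two small groups. Compound 2 and compound 3 differ by hydrogen in place of methyl on an aromatic nitrogen; on that change the step was a number 26.4 percentage points lower from compound 2 to compound 3 (beyond the scatter). Compound 3 thus stands lowest of the three numbers, and both of its gaps to the other measured compounds are beyond the scatter.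

Compound 4 `Nc1ccc2[nH]c(-c3ccc(Cl)c(Cl)c3)cc2c1` has not yet been measured. It differs from compound 3 by amino in place of nitro on an aromatic carbon. This same change, at the same place word for word, has already been measured once: compound 1 differs from compound 2 by amino in place of nitro on an aromatic carbon, and there the step was a number 8 percentage points higher from compound 2 to compound 1 (within the scatter), a movement that does not rise above the usual spread between repeated measurements. For the measured compounds named here, only this one pair is available for the change, so the expectation rests on a single observation.

Because the measured step of a number 8 percentage points higher from compound 2 to compound 1 (within the scatter) stays within the scatter, the step to compound 4 is expected to be small as well, about a number 7.4 percentage points higher from compound 3 to compound 4 (within the scatter). For compound 4 the estimate in this assay is therefore 15%, with a likely range from 2% to 30%.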

Compound 4, a percentage reported as inhibition, at one concentration (the size of the read-out at that concentration, not a potency): 21.4%
The estimate for compound 4 lay 6.4 percentage points below the measured number; measured number inside the range.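

In this assay, amino in place of nitro on an aromatic carbon gives a number 13.8 percentage points higher from compound 3 to compound 4 (beyond the scatter), and this step does not differ beyond the scatter from the one already seen for the same change on the other core: the same change on two cores in this assay, a number 8 percentage points higher (within the scatter) from compound 2 to compound 1 and a number 13.8 percentage points higher (beyond the scatter) from compound 3 to compound 4, 5.8 percentage points apart, within the scatter of two such steps. Hydrogen in place of methyl on an aromatic nitrogen, now read with amino present, gives a number 20.6 percentage points lower from compound 1 to compound 4 (beyond the scatter), and this too matches the earlier step with nitro present: the same change on two cores in this assay, a number 26.4 percentage points lower (beyond the scatter) from compound 2 to compound 3 and a number 20.6 percentage points lower (beyond the scatter) from compound 1 to compound 4, 5.8 percentage points apart, within the scatter of two such steps. Within these four compounds, then, each change behaves alike on both cores, but that rests on one pair of steps per change, all at a single concentration, and it shows neither a potency nor that the steps would hold on any further core; the amino step also clears the scatter on only one of its two cores, so even its direction is only tentatively supported.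

Still open, as far as these compounds go, is whether other groups on that aromatic carbon, such as a hydroxyl, a methoxy or an acetamide, would read like the amino or the nitro compounds. Also open, from the compounds shown here alone, is whether a longer chain on the aromatic nitrogen, such as ethyl or propyl, would carry on from methyl.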